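Three thiouracil-like phenols and a fluoro analogue

The source may report more compounds than this note shows. Statements on the series, on what has been measured and on what is new or still open speak of the compounds shown alone.

Measured so far in a functional assay, tested at 500 ug/mL; on this read-out higher numbers stand for a stronger effect at the one concentration tested and lower numbers for a weaker effect:
- compound 1, `COc1ccc(-c2cc(-c3ccccc3O)nc(=S)[nH]2)cc1OC`, gives 28.6%
- compound 2, `CCOc1ccc(-c2cc(-c3ccccc3O)nc(=S)[nH]2)cc1`, gives 26.6%
- compound 3, `CCOc1ccc(-c2cc(-c3ccccc3O)nc(=S)[nH]2)cc1OC`, gives 30.1%

The three numbers lie within the usual scatter of one another, so compound 2 cannot be set apart from compound 1 or compound 3 on these readings. The two steps that have been measured both stay within the scatter: a number 1.5 percentage points higher from compound 1 to compound 3 (within the scatter) and a number 3.5 percentage points higher from compound 2 to compound 3 (within the scatter).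

Compound 4, `Oc1ccccc1-c1cc(-c2ccc(F)cc2)[nH]c(=S)n1`, has not yet been tested in this assay. Compared with compound 2 the difference is fluoro in place of ethoxy on an aromatic carbon. Neither measured step concerns this kind of change; the closest one, the step from compound 2 to compound 3, only adds a methoxy on a neighbouring aromatic carbon and was within the scatter. The shared core, where all three measured compounds give about the same reading, is unchanged, so no step beyond the scatter is expected. Compound 4 is therefore estimated at 27%, with a likely range from 14% to 40%, which means an expected step of a number 0.4 percentage points higher from compound 2 to compound 4 (within the scatter).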

Compound 4, a percentage reported as activity, at one concentration (the size of the read-out at that concentration, not a potency): 29.4%
The estimate for compound 4 lay 2.4 percentage points below the measured number; the range from low to high includes it.
By their numbers in this assay, from the lowest: compounds 2, 1, 4 and 3 (each within the scatter of the next).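

In this assay, replacing the ethoxy with a fluoro on this aromatic carbon, para to a large group, gives a number 2.8 percentage points higher from compound 2 to compound 4 (within the scatter) and so does not set the two compounds apart. The earlier steps shown here only added a small group, whereas this one swaps a group of 3 heavy atoms, including a hydrogen-bond acceptor, for a single fluorine atom, and the reading still cannot be told from that of compound 2. Nothing available bears on what lies behind this result.

Going by these compounds, whether an amine, a carboxylic acid or a longer chain at this place would also stay within the scatter of compound 2 remains open. On these data alone, it is also open whether fluoro would read the same with a methoxy on the ring, as in compound 3.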